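A Furan Gives Way to a Larger Six-Membered Ring

The compounds below may be only part of what the source reports. "The series", "measured", "known", "first", "only" and "open" are said of these compounds alone.

Compound 1, `Cn1ccnc1-c1cc(-c2ccc(C(N)=O)cc2)cc(-c2ccc(C#N)cc2)n1`, gives 40000 nM in an assay on cells for binding affinity to Myc proto-oncogene protein (Homo sapiens); a lower number here means a stronger inhibitor, a higher number a weaker inhibitor.
Compound 2, `N#Cc1ccc(-c2cc(-c3ccccc3)cc(-c3ccco3)n2)cc1`, gives 5000 nM in this assay.
Compound 3, `N#Cc1ccc(-c2cc(-c3ccc(C(N)=O)cc3)nc(-c3ccco3)n2)cc1`, gives 7000 nM in this assay.

Among these three numbers, compound 3 holds the second highest. Its nearest neighbour is compound 2, whose value lies within the usual scatter of it, so no order between the two can be read. Compound 1 is furthest away, with a higher number that lies beyond the scatter, so compound 1 is a weaker inhibitor than compound 3.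

Compound 4, `N#Cc1ccc(-c2cc(-c3ccc(C(N)=O)cc3)nc(-c3cc[n+]([O-])cc3)n2)cc1`, has not yet been measured. It differs from compound 3 in one place: a group of 7 heavy atoms (5 carbon, 1 nitrogen, 1 oxygen; one six-membered aromatic ring with 1 hetero atom) in place of a group of 5 heavy atoms (4 carbon, 1 oxygen; one five-membered aromatic ring with 1 hetero atom), on an aromatic carbon. For the measured compounds named here, no pair of measured compounds shows this change on its own; the three measured compounds differ from one another in several places at once, so there is no measured step to lean on. The expectation for compound 4 is therefore a step of no size beyond the scatter, in either direction, with its number staying close to that of compound 3.

The estimate for compound 4 in this assay is 6000 nM, within a range from 2000 nM to 20000 nM. That estimate means the step of a 1.2-fold lower number from compound 3 to compound 4 (0.07 log units; within the scatter), expected to fall within the scatter.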

Compound 4, half-maximal inhibitory concentration in the Myc proto-oncogene protein assay: > 100000 nM
Compound 4: no number, only a limit; the forecaster's own chance of this, stated with the estimate: 10%; middle value at least 16-fold (1.22 log units) away from the limit.
By their numbers in the Myc proto-oncogene protein assay, from the lowest: compounds 2 and 3 (each within the scatter of the next); then compound 1. At a limit, above all of these: compound 4.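

For the compounds shown here, this position, on an aromatic carbon between two ring nitrogen atoms, proves sensitive to the group it carries, which the earlier compounds could not show because none of them formed a one-place pair. In the Myc proto-oncogene protein assay, replacing furan-2-yl with the larger six-membered aromatic ring gives an at least 14-fold higher number from compound 3 to compound 4 (1.15 log units; beyond the scatter), and for compound 4 the value > 100000 nM is a limit of the assay, not a number. In a physicochemical assay for solubility, at pH 6 (on this read-out lower numbers stand for lower solubility and higher numbers for higher solubility), compound 3 gives 8000 nM and compound 4 gives 25000 nM. The same change also moves the physicochemical assay in the other direction, so here higher solubility comes together with much weaker inhibition: the measured solubility of compound 3, 8000 nM, and of compound 4, 25000 nM, a 3.1-fold higher number (0.49 log units; beyond the scatter)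

Going by these compounds alone, the single change alters the ring size, the ring atoms and the oxygen on the ring nitrogen at once, so these compounds cannot tell which of these features accounts for the loss; a pyridine ring with no oxygen on its nitrogen would separate them. Going by these compounds, it also remains open whether a different group at this position, such as a thiophene ring or an amine, could keep the inhibition of compound 3 while reaching the solubility of compound 4.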